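The source may hold more compounds than are shown below. What is called first, only, known or untested is meant among the compounds shown, and "the series" means these compounds.

Of the compounds shown here, two sharing one core have been measured in a functional assay on NCI-H460 cells (Homo sapiens) for antiproliferative activity, read by CCK-8 assay, with a stated time of 72 h, tested at 8 uM; a lower number here means a weaker effect, a higher number a stronger effect of the compound at the concentration tested. Compound 1 `CC(C)n1cnc2c(Nc3cccc(Cl)c3)nc(NCOCc3ccc(C(=O)Nc4ccccc4N)cc3)nc21` gives 43.2% in this assay. Compound 2 `CCCCn1cnc2c(Nc3ccccc3)nc(NCOCc3ccc(C(=O)Nc4ccccc4N)cc3)nc21` gives 51.3% in this assay. Compound 2 has the highest of the two numbers, but the value of compound 1 lies within the usual scatter of it, so the two cannot be told apart. Compound 1 and compound 2 also differ in more than one place, so their values say nothing about a single change.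

Compound 3 `CCCCn1cnc2c(Nc3cccc(Cl)c3)nc(NCOCc3ccc(C(=O)Nc4ccccc4N)cc3)nc21` has not yet been measured. It differs from compound 2 in one place: chloro in place of hydrogen on an aromatic carbon. Among the measured compounds shown here, no measured pair isolates this change, so its effect is unknown. The step of a number 3.3 percentage points lower from compound 2 to compound 3 (within the scatter) is expected to be small, within the scatter and in no particular direction, because compound 1 also carries the chloro and gives 43.2% near the value of compound 2. Compound 3 is therefore estimated at 48%, expected to fall between 32% and 64%.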

Compound 3, a percentage reported as inhibition, at one concentration (the size of the read-out at that concentration, not a potency): 62%
Compound 3: the middle estimate sits 14 percentage points below what was measured; the range from low to high includes it.
By their numbers in this assay, from the lowest: compounds 1 and 2 (each within the scatter of the next); then compound 3.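

In this assay, chloro in place of hydrogen on the phenyl ring, with the butyl group held fixed, gives a number 10.7 percentage points higher from compound 2 to compound 3 (beyond the scatter) and so provides the first measured effect of this single change. Compound 1 and compound 3 carry the same 3-chlorophenyl group, and butyl in place of isopropyl on the aromatic nitrogen gives a number 18.8 percentage points higher from compound 1 to compound 3 (beyond the scatter), so with chloro present the read-out also responds to the group on that nitrogen. Nothing measured here explains why either step occurs.

The compounds shown leave open whether fluoro, methoxy or an amine at this place on the phenyl ring would give a step of similar size, and whether the chloro step would hold with isopropyl in place of butyl. As far as these compounds go, how a chain longer than butyl on the aromatic nitrogen would read also remains open.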